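Trading a Urea Side Chain for an Ester on the Core

A few compounds are considered here, and "the series" means these few. Any claim that something is new, unique, unknown or untested is made for them only; others in the source may bear on it.

For the measured compounds named here, compound 1 `COc1ncc(-c2ccc3nc(NC(=O)NCCN(C)C)sc3c2)cc1NS(=O)(=O)c1ccc(F)cc1` gives 240 nM in a functional assay on HCT-116 cells (Homo sapiens) for antiproliferative activity, read by MTT assay, with a stated time of 72 h (a higher number here means a weaker inhibitor, a lower number a stronger inhibitor), the lowest of the three numbers so far. Compound 2 `CNC(=O)Nc1nc2ccc(-c3cnc(OC)c(NS(=O)(=O)c4ccc(F)cc4)c3)cc2s1` gives 870 nM and compound 3 `COc1ncc(-c2ccc3nc(NC(=O)NCCN4CCCCC4)sc3c2)cc1NS(=O)(=O)c1ccc(F)cc1` gives 610 nM. Compound 4 `CCOC(=O)CNc1nc2ccc(-c3cnc(OC)c(NS(=O)(=O)c4ccc(F)cc4)c3)cc2s1` differs from compound 1 by (ethoxycarbonyl)methyl in place of (2-(dimethylamino)ethyl)carbamoyl on a nitrogen on an aromatic ring. Going by the values given here, the steps that bear on this both touch the same chain: a 3.6-fold higher number from compound 1 to compound 2 (0.56 log units; beyond the scatter) and a 2.5-fold higher number from compound 1 to compound 3 (0.41 log units; beyond the scatter). Both losing and altering the (dimethylamino)methyl part weakened inhibition, and compound 4 removes the whole chain, so a modest step toward a higher number, roughly as seen in compound 2, is expected as a 6.3-fold higher number from compound 1 to compound 4 (0.80 log units; beyond the scatter). For compound 4 the expected value is 1500 nM, within a range from 500 nM to 5000 nM.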

Compound 4, half-maximal inhibitory concentration: > 20000 nM
Compound 4: a limit, no number; the forecaster's own chance of this, stated with the estimate: 5%; middle value at least 13-fold (1.12 log units) away from the limit.
By their numbers in this assay, from the lowest: compound 1; then compounds 3 and 2 (each within the scatter of the next). At a limit, above all of these: compound 4.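

Compound 4 gives no number, only a limit of the assay: the limit of > 20000 nM in this assay, at which 1 of the 4 values shown sits. The urea compounds all stand far from it, with an at least 83-fold higher number from compound 1 to compound 4 (1.92 log units; beyond the scatter), an at least 32-fold higher number from compound 3 to compound 4 (1.51 log units; beyond the scatter) and an at least 22-fold higher number from compound 2 to compound 4 (1.36 log units; beyond the scatter), so even the small methylcarbamoyl of compound 2 keeps far more activity than (ethoxycarbonyl)methyl on this nitrogen. Changes within the urea side chain moved the number little, whereas replacing the carbamoyl itself has a large effect.

From the compounds shown here alone, whether the loss follows the missing carbamoyl or the entering ethyl ester stays open, as both change in this one step. A carboxylic acid in place of the ethyl ester, or a plain 2-(dimethylamino)ethyl chain on this nitrogen, would separate the two.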